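The source may hold more compounds than are shown below. What is called first, only, known or untested is meant among the compounds shown, and "the series" means these compounds.

In a functional assay on HT-29 cells (Homo sapiens) for cytotoxicity, read by neutral red uptake, with a stated time of 72 h (on this read-out lower numbers stand for stronger inhibition and higher numbers for weaker inhibition), compound 1 `CCCCNc1nc(SCC)nc2ncccc12` gives 25300 nM; compound 3 `CCCCCCNc1nc(SCC)nc2ncccc12` gives 22500 nM, within the scatter of that, while compound 2 `CCCCCNc1nc(SCC)nc2ncccc12` gives 5100 nM, beyond it. The step of a 5.0-fold lower number from compound 1 to compound 2 (0.70 log units; beyond the scatter) and the step of a 4.4-fold higher number from compound 2 to compound 3 (0.64 log units; beyond the scatter) both exceed the scatter, whereas a 1.1-fold lower number from compound 1 to compound 3 (0.05 log units; within the scatter) does not. Among the measured compounds shown here, compound 4 `CCCCNc1nc(SCCCC)nc2ncccc12` differs from compound 1 by ethyl in place of hydrogen on a saturated chain carbon, two bonds along the chain from a sulfur, a site none of the measured steps touch, since all of them sit on the chain four or five bonds from the nitrogen on an aromatic ring. For the measured compounds named here, no measured step bears directly on this change, and chain lengthening elsewhere went in both directions. Compound 4 is therefore expected to show a 1.4-fold lower number from compound 1 to compound 4 (0.15 log units; within the scatter), not clearly beyond the scatter. The estimate for compound 4 in this assay is 18000 nM, with a range from 6000 nM to 55000 nM.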

Compound 4, half-maximal inhibitory concentration: 13600 nM
For compound 4 the middle estimate is 1.3-fold (0.12 log units) above the measured one; low and high end bracket the measured number.
By their numbers in this assay, from the lowest: compound 2; then compounds 4, 3 and 1 (each within the scatter of the next).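

In this assay, among the compounds shown here, the change from ethylsulfanyl to butylsulfanyl gives a 1.9-fold lower number from compound 1 to compound 4 (0.27 log units; within the scatter), the first reading on the chain at the sulfur, as the earlier steps all lay on the chain at the nitrogen. Ethyl in place of hydrogen at this position therefore does not move the number clearly beyond the scatter. Nothing available explains this result. As far as these compounds go, whether a longer chain, an amine or a carboxylic acid at this position would go beyond the scatter remains open. So does whether butylsulfanyl would behave the same way with the nitrogen chain of compound 2.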